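Amide aryl swap in the flavonol series: dimethoxy variant

A few compounds are considered here, and "the series" means these few. Any claim that something is new, unique, unknown or untested is made for them only; others in the source may bear on it.

Among the measured compounds shown here, compound 1 `O=C(Nc1cccc(-c2oc3cc(-c4ccc(F)cc4)ccc3c(=O)c2O)c1)c1ccccc1F` gives 5630 nM in a functional assay on HeLa cells (Homo sapiens) for antiproliferative activity, read by CCK-8 assay, with a stated time of 72 h (a lower number here means a stronger inhibitor, a higher number a weaker inhibitor), the lowest of the three numbers measured so far. Compound 3 `COc1cccc(C(=O)Nc2cccc(-c3oc4cc(-c5ccc(F)cc5)ccc4c(=O)c3O)c2)c1` gives 5650 nM, and compound 2 `Cc1ccccc1C(=O)Nc1cccc(-c2oc3cc(-c4ccc(F)cc4)ccc3c(=O)c2O)c1` gives 11900 nM. Compound 4 `COc1cc(OC)cc(C(=O)Nc2cccc(-c3oc4cc(-c5ccc(F)cc5)ccc4c(=O)c3O)c2)c1` is not yet measured; its change from compound 1 is 3,5-dimethoxyphenyl in place of 2-fluorophenyl on a carbonyl carbon. The step that bears on it is a 1.0-fold higher number from compound 1 to compound 3 (0.00 log units; within the scatter), where a methoxyphenyl also took the place of the 2-fluorophenyl without moving the number. For the measured compounds named here, the only step beyond the scatter here, a 2.1-fold higher number from compound 1 to compound 2 (0.33 log units; beyond the scatter), concerns a different ring. A second methoxy is expected to add little, so the step from compound 1 to compound 4 is expected to read a 1.0-fold lower number from compound 1 to compound 4 (0.00 log units; within the scatter). Compound 4 is therefore estimated at 5600 nM, within 2500 nM to 13000 nM.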

Compound 4, half-maximal inhibitory concentration: 2700 nM
Compound 4: the middle estimate sits 2.1-fold (0.32 log units) above what was measured; the measured number falls inside the stated range.
By their numbers in this assay, from the lowest: compound 4; then compounds 1 and 3 (each within the scatter of the next); then compound 2.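

In this assay, the aryl group on the carbonyl carbon can lower the number, which the earlier swaps at this position did not show: a 2.1-fold lower number from compound 1 to compound 4 (0.32 log units; beyond the scatter), and a 4.4-fold lower number from compound 2 to compound 4 (0.64 log units; beyond the scatter). The added methoxy accounts for a step of its own, a 2.1-fold lower number from compound 3 to compound 4 (0.32 log units; beyond the scatter), so the 3,5-dimethoxyphenyl group separates from the 3-methoxyphenyl group here. No available evidence accounts for this step. On these data alone, whether the lower number depends on the methoxy groups themselves remains open, as does what an amine or a carboxylic acid in their place would give.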